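A Longer Hydroxycarbamoyl Chain on the Shared Core

The source may hold more compounds than are shown below. What is called first, only, known or untested is meant among the compounds shown, and "the series" means these compounds.

In a functional assay on HCT-116 cells (Homo sapiens) for inhibition, read by MTT assay, with a stated time of 72 h (on this read-out lower numbers stand for stronger inhibition and higher numbers for weaker inhibition), compound 1 (`Nc1nc2cc(-c3nn(CCCC(=O)NO)c4ncnc(N)c34)ccc2o1`) gives 19600 nM as its reading. Compound 2 (`Nc1ncnc2c1c(-c1cnc3[nH]ccc3c1)nn2CCCCCCC(=O)NO`) gives 9860 nM there, and these two values lie within the usual scatter of each other. Compound 3 (`Nc1nc2cc(-c3nn(CCCCC(=O)NO)c4ncnc(N)c34)ccc2o1`) has not yet been measured. It keeps the core of compound 1 but carries (hydroxycarbamoyl)methyl in place of hydroxycarbamoyl on a saturated chain carbon, three bonds along the chain from an aromatic nitrogen. Read further out, this is 3-(hydroxycarbamoyl)propyl to 4-(hydroxycarbamoyl)butyl. Within the data shown here, no measured pair isolates such a change, and compound 2 differs from compound 1 in more than its chain. A modest step toward stronger inhibition is therefore expected in this assay and it may not clear the scatter. The expected change is a 2.0-fold lower number from compound 1 to compound 3 (0.29 log units; within the scatter) overall. For compound 3 the estimated value is 10000 nM with an expected range of 3000 nM to 30000 nM on this measurement.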

Compound 3, half-maximal inhibitory concentration: 34000 nM
The estimate for compound 3 lay 3.4-fold (0.53 log units) below the measured number; measured number above the stated range.
By their numbers in this assay, from the lowest: compounds 2, 1 and 3 (each within the scatter of the next, the first and the last beyond it).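

In this assay, the change from 3-(hydroxycarbamoyl)propyl to 4-(hydroxycarbamoyl)butyl on the core of compound 1 reads as a 1.7-fold higher number from compound 1 to compound 3 (0.24 log units; within the scatter), and it is the first step shown that isolates this chain. At this place, on a saturated chain carbon, three bonds along the chain from an aromatic nitrogen, (hydroxycarbamoyl)methyl in place of hydroxycarbamoyl therefore leaves the two compounds indistinguishable on this read-out. No measurement shown offers an explanation for this reading.

On these data alone, whether a shorter chain such as 2-(hydroxycarbamoyl)ethyl or a longer chain such as 5-(hydroxycarbamoyl)pentyl would read beyond the scatter on this core remains open. Also open, as far as these compounds go, is how a carboxylic acid or an amine in place of the hydroxycarbamoyl end of the chain would read in this assay on this core.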